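The source may report more compounds than this note shows. Statements on the series, on what has been measured and on what is new or still open speak of the compounds shown alone.

Of the compounds shown here, three built on one shared core have been measured in an assay on brain for displacement of a labelled ligand from D(3) dopamine receptor (Rattus norvegicus); on this read-out higher numbers stand for weaker inhibition and lower numbers for stronger inhibition. Compound 1 `CCCN(CC[C@H]1CC[C@H](NC(=O)/C=C/c2ccccc2Cl)CC1)[C@H]1CCc2nc(N)sc2C1` gives 1.2 nM. Compound 2 `CCCN(CC[C@H]1CC[C@H](NS(=O)(=O)c2ccc(OC)cc2)CC1)[C@H]1CCc2nc(N)sc2C1` gives 0.78 nM in this assay. Compound 3 `CCCN(CC[C@H]1CC[C@H](NS(=O)(=O)c2cccc(Cl)c2)CC1)[C@H]1CCc2nc(N)sc2C1` gives 1.1 nM in this assay. Among these three numbers compound 3 has the second highest, yet its steps to both neighbours, a 1.1-fold lower number from compound 1 to compound 3 (0.04 log units; within the scatter) and a 1.4-fold higher number from compound 2 to compound 3 (0.15 log units; within the scatter), lie within the scatter, so no order among the three can be claimed.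

Compound 4 `CCCN(CC[C@H]1CC[C@H](NS(=O)(=O)c2ccc(C(C)C)cc2)CC1)[C@H]1CCc2nc(N)sc2C1` is a further member of the set, not yet measured. It differs from compound 3 in one place: 4-isopropylphenyl in place of 3-chlorophenyl on a sulfonyl sulfur. Among the compounds with values here, only one measured step changes the group on the sulfonyl sulfur, a 1.4-fold higher number from compound 2 to compound 3 (0.15 log units; within the scatter), and it stayed within the scatter. The replacement of the (2-(2-chlorophenyl)ethenyl)carbonyl group by either sulfonyl group, a 1.5-fold lower number from compound 1 to compound 2 (0.19 log units; within the scatter) and a 1.1-fold lower number from compound 1 to compound 3 (0.04 log units; within the scatter), also left the number within the scatter. Since every variation at this end of the molecule has produced no step beyond the scatter, compound 4 is expected to show none either, a 1.1-fold higher number from compound 3 to compound 4 (0.04 log units; within the scatter). The estimated value for compound 4 in this assay is 1.2 nM, with a range from 0.4 nM to 3.5 nM.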

Compound 4, inhibition constant: 4.5 nM
Compound 4: middle estimate off by 3.8-fold (0.57 log units), on the low side; the measured number lies above the stated range.
By their numbers in this assay, from the lowest: compounds 2, 3 and 1 (each within the scatter of the next); then compound 4.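

In this assay, the group on the sulfonyl sulfur proves able to shift the number: 4-isopropylphenyl in place of 3-chlorophenyl gives a 4.1-fold higher number from compound 3 to compound 4 (0.61 log units; beyond the scatter), and isopropyl in place of methoxy on an aromatic carbon gives a 5.8-fold higher number from compound 2 to compound 4 (0.76 log units; beyond the scatter). Within the data shown here, these are the first steps at this end of the molecule to pass beyond the scatter, and although both are modest, they point the same way, setting compound 4 apart from two sulfonamides that remain within the scatter of each other. No supporting data bear on why the 4-isopropylphenyl group behaves this way.

Going by these compounds, whether the higher number follows the isopropyl group itself or its place on the ring remains open, and 3-isopropylphenyl and 4-chlorophenyl groups on the sulfonyl sulfur would help to separate the two. Also open, on these data alone, is whether a 4-methylphenyl or 4-tert-butylphenyl group at the same position would give a number close to that of compound 2 or close to that of compound 4.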